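The source may report more compounds than this note shows. Statements on the series, on what has been measured and on what is new or still open speak of the compounds shown alone.

Measured so far:
compound 1, `ClCc1cccc(Cn2cnc3ncnc(Cl)c32)c1`: 32400 nM
compound 2, `ClCc1ccc(Cn2cnc3nc(Cl)nc(Cl)c32)cc1`: 28800 nM
compound 3, `ClCc1ccccc1Cn1cnc2nc(Cl)nc(Cl)c21`: 670 nM

All three numbers come from a functional assay on SW-620 cells (Homo sapiens) for cytotoxicity, read by sulforhodamine B assay, with a stated time of 48 h; on this read-out higher numbers stand for weaker inhibition of growth and lower numbers for stronger inhibition of growth. Compound 2 holds the second highest of the three; compound 1 lies nearest, within the scatter, and compound 3 lies furthest, well beyond it. Compound 4, `ClCc1ccc(Cn2cnc3ncnc(Cl)c32)cc1`, has not yet been measured in this assay. It differs from compound 2 in one place: hydrogen in place of chloro on an aromatic carbon. Among the compounds with values here, no measured pair differs in this place alone, so the size of the step is unknown. Compound 1, whose core also carries a single chloro, gives a number close to that of compound 2, which gives no hint of a large shift. The expected step is a 1.0-fold higher number from compound 2 to compound 4 (0.02 log units; within the scatter), within the scatter. Compound 4 is estimated at 30000 nM, with a range of 10000 nM to 90000 nM.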

Compound 4, concentration for total growth inhibition: 7240 nM
The estimate for compound 4 lay 4.1-fold (0.62 log units) above the measured number; measured number outside the range, below it.
By their numbers in this assay, from the lowest: compound 3; then compound 4; then compounds 2 and 1 (each within the scatter of the next).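

In this assay, hydrogen in place of chloro on the aromatic carbon between two ring nitrogen atoms gives a 4.0-fold lower number from compound 2 to compound 4 (0.60 log units; beyond the scatter). Within the data shown here, this is the first read on this position: the chloro is not required for growth inhibition in this pair, and its loss lowers the number rather than leaving it unchanged. Nothing at hand accounts for the shift.

Still open, as far as these compounds go, is how an amine or a methoxy group on this carbon would compare with hydrogen and chloro. Also open, from the compounds shown here alone, is whether the step carries over to the arrangement of compound 3.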